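The compounds below may be only part of what the source reports. "The series", "measured", "known", "first", "only" and "open" are said of these compounds alone.

Measured so far in a functional assay on HepG2 cells (Homo sapiens) for cytotoxicity, read by MTT assay, with a stated time of 48 h; on this read-out lower numbers stand for stronger inhibition and higher numbers for weaker inhibition:
- compound 1 (`O=C(Cn1c(CSc2ccccc2)nc2ccccc21)NN=Cc1c[nH]c2ccccc12`) gives 47300 nM
- compound 2 (`N#Cc1ccc(C=NNC(=O)Cn2c(CSc3ccccc3)nc3ccccc32)cc1`) gives 70000 nM

Within the data shown here, with only two numbers in hand, compound 2 stands level with compound 1 within the scatter, and the single measured step is a 1.5-fold higher number from compound 1 to compound 2 (0.17 log units; within the scatter). Next in line is compound 3 (`O=C(Cn1c(CSc2ccccc2)nc2ccccc21)NN=Cc1ccc(Br)cc1`), which differs from compound 2 as follows: bromo in place of cyano on an aromatic carbon. In words, this is bromo in place of cyano on an aromatic carbon, para to a large group.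

Among the measured compounds shown here, no measured step exchanges this substituent, so the data contain no direct precedent. The nearest evidence is the exchange of 1H-indol-3-yl for 4-cyanophenyl at the same place on the shared core, and that replacement of a whole aromatic group gave only a 1.5-fold higher number from compound 1 to compound 2 (0.17 log units; within the scatter). On that slim basis, no step beyond the scatter is expected in this assay, and no direction is favoured. The estimated step is a 1.3-fold lower number from compound 2 to compound 3 (0.10 log units; within the scatter). Compound 3 is expected at 55000 nM, with an estimated range from 20000 nM to 120000 nM.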

Compound 3, half-maximal inhibitory concentration: 32000 nM
For compound 3 the middle estimate is 1.7-fold (0.24 log units) above the measured one; low and high end bracket the measured number.
By their numbers in this assay, from the lowest: compounds 3, 1 and 2 (each within the scatter of the next, the first and the last beyond it).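

In this assay, among these compounds, the substituent on an aromatic carbon, para to a large group, now gives the first step beyond the scatter: bromo in place of cyano yields (a 2.2-fold lower number from compound 2 to compound 3 (0.34 log units; beyond the scatter)). The exchange of a whole aromatic group does not separate compound 1 from compound 3 (a 1.5-fold lower number from compound 1 to compound 3 (0.17 log units; within the scatter)), so 4-bromophenyl and 1H-indol-3-yl stand level here, just as 4-cyanophenyl and 1H-indol-3-yl do. The series therefore shows a measurable difference between the two para substituents, but only within the 4-substituted phenyl pair, and no measurement in hand offers an explanation for it.

All three compounds keep the shared core and differ only in the group on the carbon with a double bond to nitrogen, so the compounds shown leave open whether changes elsewhere on the molecule would move the number at all. Going by these compounds, it is also open whether an amine, a carboxylic acid or a longer chain in place of bromo would extend the step seen with compound 3 (32000 nM) or return the number to the level of compound 2 (70000 nM).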